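From a Second Amidoxime Arm to a Single Bromine Atom

This account rests on a few compounds, and the source may have more. Where it says the series, first, only, none or still open, it means among the compounds named here.

Compound 1, `CC1(c2ccc(-c3ccco3)cc2)CC(S(=O)(=O)c2ccc(F)cc2)=C(c2ccc(/C(N)=N\O)cc2)O1`: 7010 nM
Compound 2, `Cc1ccc(-c2ccc(C3(C)CC(S(=O)(=O)c4ccc(F)cc4)=C(c4ccc(/C(N)=N\O)cc4)O3)cc2)cc1`: 13700 nM
Compound 3, `CC1(c2ccc(-c3cccc(/C(N)=N\O)c3)cc2)CC(S(=O)(=O)c2ccc(F)cc2)=C(c2ccc(/C(N)=N\O)cc2)O1`: 19000 nM
Compound 4, `CC1(c2ccc(Br)cc2)CC(S(=O)(=O)c2ccc(F)cc2)=C(c2ccc(/C(N)=N\O)cc2)O1`: not yet measured

In an ADME assay on HepG2 cells (Homo sapiens) for cytotoxicity, read by MTT assay, with a stated time of 72 h (on this read-out lower numbers stand for higher toxicity in this test and higher numbers for lower toxicity in this test), compound 3 holds the highest of the three numbers, but a 1.4-fold higher number from compound 2 to compound 3 (0.14 log units; within the scatter) is within the scatter, so compound 3 and compound 2 cannot be told apart; only a 2.7-fold higher number from compound 1 to compound 3 (0.43 log units; beyond the scatter) is beyond it. Compound 4 differs from compound 3 by one bromine atom in place of a group of 10 heavy atoms (7 carbon, 2 nitrogen, 1 oxygen; one six-membered aromatic ring of carbon only), on an aromatic carbon. The two steps into compound 3 both put the larger group at this same place and both raised the number, one modestly and one within the scatter. Taking that group away for a bromine atom is therefore expected to lower the number again, modestly at most. For compound 4 the expected step is a 2.4-fold lower number from compound 3 to compound 4 (0.38 log units; beyond the scatter). Compound 4 is estimated at 8000 nM, between 3500 nM and 18000 nM.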

Compound 4, half-maximal cytotoxic concentration: 19200 nM
For compound 4 the middle estimate is 2.4-fold (0.38 log units) below the measured one; measured number above the stated range.
By their numbers in this assay, from the lowest: compounds 1, 2, 3 and 4 (each within the scatter of the next, the first and the last beyond it).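

In this assay, the large group on this aromatic carbon proves dispensable: a single bromine atom gives a reading that cannot be told apart from it, a 1.0-fold higher number from compound 3 to compound 4 (0.00 log units; within the scatter). Bromo also cannot be separated from 4-methylphenyl, a 1.4-fold higher number from compound 2 to compound 4 (0.15 log units; within the scatter), so size alone does not order these compounds, and only furan-2-yl stands apart, a 2.7-fold higher number from compound 1 to compound 4 (0.44 log units; beyond the scatter). No supporting measurement bears on why this is so.

Going by these compounds, it remains open whether an amine or a carboxylic acid at this place would read like compound 4 or like compound 1.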